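A few compounds are considered here, and "the series" means these few. Any claim that something is new, unique, unknown or untested is made for them only; others in the source may bear on it.

Measured so far:
- compound 1 `C[C@@H]1CN(S(=O)(=O)c2ccc(NC(=O)NCc3cccnc3)cc2)C[C@H](C)O1` gives 4 nM
- compound 2 `O=C(NCc1cccnc1)Nc1ccc(S(=O)(=O)N2CCCNCC2)cc1` gives 45 nM
- compound 3 `CC1CNCCN(S(=O)(=O)c2ccc(NC(=O)NCc3cccnc3)cc2)C1` gives 100 nM

All three values come from an assay on isolated protein for inhibition of Nicotinamide phosphoribosyltransferase (Homo sapiens), read by spectrophotometry, with stated times of 15 min and 30 min; a higher number here means a weaker inhibitor, a lower number a stronger inhibitor. On these numbers compound 3 stands at the highest value of the three: the nearest is compound 2, the furthest is compound 1, and both gaps are beyond the scatter.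

Compound 4 `CC1CCN(S(=O)(=O)c2ccc(NC(=O)NCc3cccnc3)cc2)CCN1` has the same atoms as compound 3, joined differently: a group of 8 heavy atoms (6 carbon, 2 nitrogen; one seven-membered non-aromatic ring with 2 hetero atoms) in place of a group of 8 heavy atoms (6 carbon, 2 nitrogen; one seven-membered non-aromatic ring with 2 hetero atoms), on a sulfonyl sulfur. Among the measured compounds shown here, the ring on the sulfonyl sulfur is the part of the series that has moved the numbers so far. The step of a 25-fold higher number from compound 1 to compound 3 (1.40 log units; beyond the scatter) and the step of an 11-fold higher number from compound 1 to compound 2 (1.05 log units; beyond the scatter) were large, both rising as the six-membered ring gave way to the seven-membered one. The step of a 2.2-fold higher number from compound 2 to compound 3 (0.35 log units; beyond the scatter) was modest, the addition of the methyl on a saturated ring carbon. For the measured compounds named here, no measured pair shows a methyl relocated within the same ring, so the closest guide is the modest size of the step from compound 2 to compound 3, which bounds how much a methyl has mattered here.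

The expectation for compound 4 is therefore a step of about a 1.3-fold lower number from compound 3 to compound 4 (0.10 log units; within the scatter), likely within the scatter or a small fall, with compound 4 estimated at 80 nM in this assay, range 35 nM to 200 nM.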

Compound 4, half-maximal inhibitory concentration: 11 nM
Compound 4: middle estimate off by 7.3-fold (0.86 log units), on the high side, and the stated range ends above it.
By their numbers in this assay, from the lowest: compound 1; then compound 4; then compound 2; then compound 3.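

Working notes on the ring on the sulfonyl sulfur: in this assay the placement of the methyl within the seven-membered ring matters far more than the earlier compounds suggested, with a 9.1-fold lower number from compound 3 to compound 4 (0.96 log units; beyond the scatter) for a change that leaves the counted atoms, donors and acceptors untouched. Adding a methyl in place of hydrogen on a saturated ring carbon can also move the number either way, since a 4.1-fold lower number from compound 2 to compound 4 (0.61 log units; beyond the scatter) stands against a 2.2-fold higher number from compound 2 to compound 3 (0.35 log units; beyond the scatter) for the other placement, so the methyl has no single effect in the series. The seven-membered ring also no longer goes with a large loss against the dimethylmorpholine, with a 2.8-fold higher number from compound 1 to compound 4 (0.44 log units; beyond the scatter) as a modest step that still leaves compound 1 ahead, and compound 4 goes against the pattern set by compound 2 and compound 3, though no data shown here account for any of these shifts.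

On these data alone, it remains open whether an ethyl or a hydroxymethyl at the methyl-bearing ring carbon of compound 4 would hold or lose the number in this assay. The compounds shown also leave open how an acetyl on the ring nitrogen would read, and how each separate mirror-image form of compound 4 compares.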